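The source may report more compounds than this note shows. Statements on the series, on what has been measured and on what is new or still open speak of the compounds shown alone.

Compound 1 `CCc1cc(C(C)=O)c(O)cc1OCCCCC#N` is one of two compounds examined in an assay on isolated protein for inhibition of leukotriene B4 receptor 1 (Homo sapiens), tested at 10 uM; a lower number here means less inhibition, a higher number more inhibition at the concentration tested (going by the name of the read-out). In this assay compound 1 gives 92%, and compound 2 `CCCc1cc(C(C)=O)c(O)cc1OCCCCC#N` gives 84%; the step of a number 8 percentage points lower from compound 1 to compound 2 (within the scatter) means the two numbers cannot be told apart, so compound 1 is not ranked above or below compound 2. Compound 3 `CCc1cc(C(C)=O)c(O)cc1OCCCCCC(C)(C)C#N` has not yet been measured. It differs from compound 1 by 2-cyano-2-methylpropyl in place of cyano on a saturated chain carbon, four bonds along the chain from an oxygen on an aromatic ring. Among the measured compounds shown here, the only measured step, a number 8 percentage points lower from compound 1 to compound 2 (within the scatter), concerns a methyl added on the chain that sits on the other side of the shared core, not the end of the chain carrying the nitrile, so it bears only loosely on this change; no measured step touches the nitrile end itself. The expected step is therefore small, a number 8 percentage points lower from compound 1 to compound 3 (within the scatter), with no direction beyond the scatter. For compound 3 the estimate in this assay is 84%, within the range 62% to 97%.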

Compound 3, a percentage reported as inhibition, at one concentration (the size of the read-out at that concentration, not a potency): 85%
The estimate for compound 3 lay 1 percentage points below the measured number; the measured number falls inside the stated range.
By their numbers in this assay, from the lowest: compounds 2, 3 and 1 (each within the scatter of the next).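

In this assay the step of a number 7 percentage points lower from compound 1 to compound 3 (within the scatter) comes with 2-cyano-2-methylpropyl in place of cyano on a saturated chain carbon, four bonds along the chain from an oxygen on an aromatic ring. Among the compounds shown here, this is the first measured change at the nitrile end of the chain, and it shows that a group of 6 heavy atoms can stand in place of one of 2, with the nitrile kept, without a difference that can be read at this one concentration. No measurement shown accounts for this result.

Going by these compounds, both groups end in a nitrile, so the effect of ending the chain in a carboxylic acid or an amine stays open. On these data alone, a percentage at one concentration is not a potency, and any difference in potency between compound 1 and compound 3 also stays open.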